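A few compounds are considered here, and "the series" means these few. Any claim that something is new, unique, unknown or untested is made for them only; others in the source may bear on it.

Compound 1 `O=C(NCCNc1ccc(F)cc1)[C@H](CC1CCCCC1)Nc1nc2ccccc2o1` stands at the lower of the two numbers in an assay on isolated protein for inhibition of cathepsin S (Homo sapiens); on this read-out higher numbers stand for weaker inhibition and lower numbers for stronger inhibition: compound 1 gives 94 nM. Among the compounds with values here, its only measured neighbour is compound 2 `O=C(NCCNc1ccc(F)cc1)[C@H](CC1CCCCC1)Nc1nc2cc(F)ccc2o1`, which in this assay gives 197 nM; the step of a 2.1-fold higher number from compound 1 to compound 2 (0.32 log units; beyond the scatter) is the one comparison available so far. Compound 3 `COC(=O)c1ccc2nc(N[C@@H](CC3CCCCC3)C(=O)NCCNc3ccc(F)cc3)oc2c1` has not yet been measured; it differs from compound 1 by methoxycarbonyl in place of hydrogen on an aromatic carbon. The step to compound 2 is the only one that bears on this change, since both put a substituent on an aromatic carbon of the fused part of the shared core, and that step was modest; the entering group here is a different and larger one, so the step from compound 1 to compound 2 is read only as a loose guide. A change of similar size and direction is expected, near the edge of the scatter. For compound 3 the expected step is a 1.9-fold higher number from compound 1 to compound 3 (0.28 log units; within the scatter). Compound 3 is expected to give 180 nM, within 60 nM to 550 nM.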

Compound 3, inhibition constant: 43 nM
Estimate against measurement, compound 3: 4.2-fold (0.62 log units) above; the measured number lies below the stated range.
By their numbers in this assay, from the lowest: compound 3; then compound 1; then compound 2.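

In this assay, methoxycarbonyl on this aromatic carbon gives a 2.2-fold lower number from compound 1 to compound 3 (0.34 log units; beyond the scatter), so a group of four heavy atoms is tolerated here without loss of inhibition, and the number moves the opposite way to a 2.1-fold higher number from compound 1 to compound 2 (0.32 log units; beyond the scatter). The fluoro of compound 2 stands on a different aromatic carbon of the shared core, so these two steps do not separate the effect of the group from that of its place. Nothing at hand accounts for the lower number of compound 3.

On these data alone, it remains open whether the change depends on methoxycarbonyl itself or would also appear with a carboxylic acid, a primary amide or a methyl group on this carbon. Also open, as far as these compounds go, is how methoxycarbonyl would read on the carbon that bears fluoro in compound 2, and fluoro on the carbon that bears methoxycarbonyl in compound 3.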